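The source may hold more compounds than are shown below. What is called first, only, known or untested is meant among the compounds shown, and "the series" means these compounds.

Compound 1 `CCCCCCCCCCCCNC(=O)[C@@H](NC(=O)c1ccco1)[C@@H](C)O` gives 64300 nM in a functional assay on SiHa cells (Homo sapiens) for cytotoxicity, read by MTT assay, with a stated time of 48 h; a lower number here means a stronger inhibitor, a higher number a weaker inhibitor. Compound 2 `C/C=C/C=C/C(=O)N[C@H](C(=O)NCCCCCCCCCCCC)[C@@H](C)O` gives > 200000 nM in this assay, which is a limit of the assay and not a number.

Compound 2 therefore stands at the weak end of what is known: of the two values shown, it is the one that sits at the limit of > 200000 nM in this assay, at which 1 of the 2 values shown sits, and the step of an at least 3.1-fold higher number from compound 1 to compound 2 (0.49 log units; beyond the scatter) shows that exchanging the group on the carbonyl carbon moved the read-out by an amount beyond the scatter. Compound 3 `CCCCCCCCCCCCNC(=O)[C@@H](NS(=O)(=O)c1ccc(C)cc1)[C@@H](C)O` changes the same position again: (4-methylphenyl)sulfonyl in place of (penta-1,3-dien-1-yl)carbonyl on an amine nitrogen. Among the measured compounds shown here, no measured step concerns a sulfonyl group on this nitrogen, so the only guide is that the acyl exchange between compound 1 and compound 2 shifted the number by the size of an at least 3.1-fold higher number from compound 1 to compound 2 (0.49 log units; beyond the scatter). Since compound 2 already sits at the limit, a further upward step cannot be resolved, and a downward step is estimated only tentatively. Compound 3 is expected to give 120000 nM (range 30000 nM to 400000 nM), which would mean an estimated step of an at least 1.6-fold lower number from compound 2 to compound 3 (0.22 log units; that floor lies within the scatter).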

Compound 3, half-maximal inhibitory concentration: 31600 nM
Estimate against measurement, compound 3: 3.8-fold (0.58 log units) above; low and high end bracket the measured number.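

In this assay, this amine nitrogen now carries a sulfonyl group instead of an acyl group, and the number falls relative to both acyl compounds: exchanging (penta-1,3-dien-1-yl)carbonyl for (4-methylphenyl)sulfonyl gives an at least 6.3-fold lower number from compound 2 to compound 3 (0.80 log units; beyond the scatter), and exchanging (furan-2-yl)carbonyl for it gives a 2.0-fold lower number from compound 1 to compound 3 (0.31 log units; beyond the scatter). Among the compounds shown here, compound 2 remains a limit of the assay, so the first of these steps gives a floor and not a full size: the limit of > 200000 nM in this assay, at which 1 of the 3 values shown sits. The earlier compounds showed only that the read-out changes between two acyl groups, whereas compound 3 shows that the carbonyl on this nitrogen can be replaced by a sulfonyl group without losing the read-out, and its steps to both others place it as the strongest of the three.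

The exchange changes the linking group and the attached group at once, so the compounds shown cannot separate the sulfonyl group from the 4-methylphenyl ring; a benzoyl group or an unsubstituted phenylsulfonyl group on this nitrogen would bear on that. From the compounds shown here alone, whether the same order holds with a shorter chain on the shared core, or with a free amine at this nitrogen, also stays open.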